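Replacing the aryl group of compound 2

The source may report more compounds than this note shows. Statements on the series, on what has been measured and on what is new or still open speak of the compounds shown alone.

In a functional assay on NCI-H727 cells (Homo sapiens) for cytotoxicity, with a stated time of 48 h (on this read-out lower numbers stand for stronger inhibition and higher numbers for weaker inhibition), three compounds sharing a core have been measured. Here compound 1 (`COc1cc(OC)c(C(=O)/C=C/c2ccccc2OC)c(OC)c1`) gives 4000 nM and compound 2 (`COc1cc(OC)c(C(=O)/C=C/c2ccccc2SC)c(OC)c1`) gives 8700 nM while compound 3 (`COc1cccc(/C=C/C(=O)c2c(OC)cc(OC)cc2OC)c1`) gives 8200 nM on the same scale. Compound 2 sits at the upper end of these numbers together with compound 3, the gap being a 1.1-fold lower number from compound 2 to compound 3 (0.03 log units; within the scatter) while compound 1 stands apart, with a 2.2-fold higher number from compound 1 to compound 2 (0.34 log units; beyond the scatter) as the measured step.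

The unmeasured compound 4 (`COc1cc(OC)c(C(=O)/C=C/c2ccc(Br)cc2)c(OC)c1`) is reached from compound 2 by one change: 4-bromophenyl in place of 2-(methylsulfanyl)phenyl on a double-bonded chain carbon bound to a double-bonded chain carbon in that single place. Within the data shown here, no measured compound carries the 4-bromophenyl group, so no step speaks to it directly. Among the measured compounds shown here, the closest precedent is compound 3, where the same 2-(methylsulfanyl)phenyl also leaves and the step stays within the scatter. The other two changes on this aromatic group are modest: a 2.1-fold higher number from compound 1 to compound 3 (0.31 log units; beyond the scatter) and the methoxy to methylsulfanyl step already given.

A small move toward a lower number is therefore expected, with no step beyond the scatter: the estimate is a 1.5-fold lower number from compound 2 to compound 4 (0.16 log units; within the scatter) for this change. In this assay the estimated value for compound 4 is 6000 nM with an expected range from 2500 nM to 14000 nM as its limits.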

Compound 4, half-maximal inhibitory concentration: 11300 nM
Compound 4: middle estimate off by 1.9-fold (0.27 log units), on the low side; measured number inside the range.
By their numbers in this assay, from the lowest: compound 1; then compounds 3, 2 and 4 (each within the scatter of the next).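

In this assay, the 4-bromophenyl group on a double-bonded chain carbon bound to a double-bonded chain carbon falls in with the 2-(methylsulfanyl)phenyl and 3-methoxyphenyl groups (a 1.3-fold higher number from compound 2 to compound 4 (0.11 log units; within the scatter); a 1.4-fold higher number from compound 3 to compound 4 (0.14 log units; within the scatter)). The exchange at this place therefore tolerates a group with bromine and 0 hydrogen-bond acceptors entering for one with sulfur and 1 hydrogen-bond acceptor, without a step beyond the scatter. Among these compounds, compound 1 with its 2-methoxyphenyl group remains the exception, and the gap to the new group is the largest step at this place so far (a 2.8-fold higher number from compound 1 to compound 4 (0.45 log units; beyond the scatter)), so the separation of compound 1 now rests on three comparisons rather than two.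

Still open is whether the separation of compound 1 belongs to the 2-methoxyphenyl group alone, since the compounds shown do not include a phenyl group carrying an amine or a carboxylic acid at this place. As far as these compounds go, it is also open whether the bromine itself matters, as no unsubstituted phenyl group or 2-bromophenyl group stands for comparison. Nothing measured here accounts for the grouping of these numbers.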